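A few compounds are considered here, and "the series" means these few. Any claim that something is new, unique, unknown or untested is made for them only; others in the source may bear on it.

Going by the values given here, in a functional assay on MDA-MB-231 cells (Homo sapiens) for cytotoxicity, read by MTT assay, with a stated time of 72 h (on this read-out lower numbers stand for stronger inhibition and higher numbers for weaker inhibition), compound 1 `Nc1ccccc1NC(=O)c1ccc(NC(=S)NCc2ccc(Cl)nc2)cc1` gives 42000 nM, the only actual number among the compounds tested so far. Compound 2 `Nc1ccccc1NC(=O)c1ccc(Cn2cc(-c3ccc(NC(=O)NCc4cccnc4)cc3)nn2)cc1` reaches only a limit of the assay, > 100000 nM. Compound 3 `Cc1ccc(CNC(=S)Nc2ccc(C(=O)Nc3ccccc3N)cc2)cn1` has yet to be measured. It departs from compound 1 at a single place: methyl in place of chloro on an aromatic carbon. This puts methyl in place of chloro on an aromatic carbon, next to the ring nitrogen and para to a large group, so that 6-chloropyridin-3-yl becomes 6-methylpyridin-3-yl. Among the compounds with values here, no measured pair of compounds shows what this exchange does in this assay, so the expectation rests on the value of compound 1 alone. The expected change, a 1.1-fold higher number from compound 1 to compound 3 (0.03 log units; within the scatter), is estimated to stay within the scatter, with neither direction favoured. Compound 3 is therefore expected at about 45000 nM, within an estimated range of 18000 nM to 100000 nM.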

Compound 3, half-maximal inhibitory concentration: 63000 nM
For compound 3 the middle estimate is 1.4-fold (0.15 log units) below the measured one; low and high end bracket the measured number.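

In this assay, the exchange now has its first measured step, a 1.5-fold higher number from compound 1 to compound 3 (0.18 log units; within the scatter), so this assay does not tell methyl and chloro apart at this position. The number seen for compound 1 therefore does not depend on the chloro group: with methyl on the same aromatic carbon, 6-methylpyridin-3-yl serves as well as 6-chloropyridin-3-yl. Compound 1 and compound 3 both give actual numbers, whereas compound 2 reaches a limit of the assay and not a number: the limit of > 100000 nM in this assay, at which 1 of the 3 values shown sits.

The compounds shown leave open whether a different group on this carbon, such as an amine, a methoxy group or a carboxylic acid, would move the number beyond the scatter. They also leave open whether methyl and chloro would stay equivalent on another core.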